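Extending the Chain From Compound 2 to Compound 3

This account rests on a few compounds, and the source may have more. Where it says the series, first, only, none or still open, it means among the compounds named here.

Measured in a functional assay on EC9706 cells (Homo sapiens) for antiproliferative activity, read by MTT assay, with a stated time of 48 h; on this read-out higher numbers stand for weaker inhibition and lower numbers for stronger inhibition:
Compound 1 `CCCCCCCCCn1cc(COC[C@@H]2OC[C@H](N)[C@H]2O)nn1`: > 128000 nM (a limit of the assay)
Compound 2 `CCCCCCCCCCn1cc(COC[C@@H]2OC[C@H](N)[C@H]2O)nn1`: 43100 nM

Within the data shown here, compound 2 , at 43100 nM, holds the only exact number so far. Compound 1 gives only a limit, (the limit of > 128000 nM in this assay, at which 1 of the 2 values shown sits). Compound 3 `CCCCCCCCCCCCCCCCn1cc(COC[C@@H]2OC[C@H](N)[C@H]2O)nn1` differs from compound 2 by hexyl in place of hydrogen on a saturated chain carbon, ten or more bonds along the chain from an aromatic nitrogen. Among the measured compounds shown here, the one measured step bearing on this change is an at least 2.9-fold lower number from compound 1 to compound 2 (0.47 log units; beyond the scatter), which lies beyond the scatter. A further fall in this assay is therefore expected, though one step is thin support. The expected change is a 2.9-fold lower number from compound 2 to compound 3 (0.46 log units; beyond the scatter). Compound 3 is estimated at 15000 nM, with an expected range of 4000 nM to 60000 nM.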

Compound 3, half-maximal inhibitory concentration: 6310 nM
Compound 3: the middle estimate sits 2.4-fold (0.38 log units) above what was measured; the range from low to high includes it.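

In this assay, the fall in the number does not stop at compound 2: hexyl in place of hydrogen on a saturated chain carbon gives a 6.8-fold lower number from compound 2 to compound 3 (0.83 log units; beyond the scatter). Taken over the whole length, the change gives an at least 20-fold lower number from compound 1 to compound 3 (1.30 log units; beyond the scatter). Compound 1 remains a limit of the assay, so this wider span has no exact size: the limit of > 128000 nM in this assay, at which 1 of the 3 values shown sits.

Going by these compounds, whether a longer chain would lower the number further or reverse the trend stays open. So does the effect of an amine or a carboxylic acid in place of the hexyl.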